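A few compounds are considered here, and "the series" means these few. Any claim that something is new, unique, unknown or untested is made for them only; others in the source may bear on it.

Compound 1 `N#Cc1c(N)nc(SCC(=O)NCO)c(C#N)c1-c1ccc(OCC2CC2)cc1` gives 10% in an assay on CHO cells for displacement of a labelled ligand from adenosine receptor A1 (Homo sapiens), read by scintillation counting, with a stated time of 90 min, tested at 1 uM; a higher number here means more inhibition at the concentration tested (going by the name of the read-out), a lower number less inhibition. Within the data shown here, compound 2 `N#Cc1c(N)nc(SCc2nc3ccccc3[nH]2)c(C#N)c1-c1ccc(OCC2CC2)cc1` gives 21% in this assay, and the one measured step, a number 11 percentage points higher from compound 1 to compound 2 (beyond the scatter), is the only comparison at this position. On these two numbers compound 2 stands highest, with compound 1 the nearest below it. Compound 3 `N#Cc1c(N)nc(SCn2cncn2)c(C#N)c1-c1ccc(OCC2CC2)cc1` is not yet measured; it differs from compound 2 by 1H-1,2,4-triazol-1-yl in place of 1H-benzimidazol-2-yl on a saturated chain carbon bound to a sulfur. Among the measured compounds shown here, no measured pair shows this exact exchange, so only the modest step of a number 11 percentage points higher from compound 1 to compound 2 (beyond the scatter) bears on it. The expected step is a number 6 percentage points lower from compound 2 to compound 3 (within the scatter), a small fall or nothing beyond the scatter. Compound 3 is estimated at 15% in this assay, within 3% to 30%.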

Compound 3, a percentage reported as inhibition, at one concentration (the size of the read-out at that concentration, not a potency): 12%
Estimate against measurement, compound 3: 3 percentage points above; the range from low to high includes it.
By their numbers in this assay, from the lowest: compounds 1, 3 and 2 (each within the scatter of the next, the first and the last beyond it).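

In this assay there is a number 9 percentage points lower from compound 2 to compound 3 (within the scatter) on going to the 1H-1,2,4-triazol-1-yl group, and a number 2 percentage points higher from compound 1 to compound 3 (within the scatter) against the (hydroxymethyl)carbamoyl group. Among these compounds, compound 3 therefore cannot be separated from either neighbour, and the only gap beyond the scatter at this position remains the one between compound 1 and compound 2. The smaller aromatic ring, with no hydrogen-bond donor, is thus not separated from the larger 1H-benzimidazol-2-yl group by this read-out.

As far as these compounds go, how an amine or a carboxylic acid on the same saturated chain carbon, or a longer chain before the ring, would read stays open. Nothing measured here gives a cause for these numbers.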